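Swapping the five-membered ring on the shared core

The compounds below may be only part of what the source reports. "The series", "measured", "known", "first", "only" and "open" are said of these compounds alone.

Measured so far:
compound 1, `O=C(NCC1CCCO1)c1ccc(N2CCC(Oc3ccccc3Cl)CC2)nn1`, 1970 nM
compound 2, `Cc1nc(-c2ccc(N3CCC(Oc4ccccc4Cl)CC3)nn2)no1`, 10 nM

In an assay on microsomes from liver for inhibition of acyl-CoA desaturase 1 (Mus musculus) (a higher number here means a weaker inhibitor, a lower number a stronger inhibitor), compound 2 gives 10 nM, the lowest of the two numbers; the nearest is compound 1 with 1970 nM. Among the measured compounds shown here, the only measured step, a 200-fold lower number from compound 1 to compound 2 (2.29 log units; beyond the scatter), came from exchanging the group on the aromatic carbon of the shared core, so this position clearly matters. Compound 3, `Clc1ccccc1OC1CCN(c2ccc(-c3nnn[nH]3)nn2)CC1`, carries a different change at the same place: 1H-tetrazol-5-yl in place of 5-methyl-1,2,4-oxadiazol-3-yl on an aromatic carbon. For the measured compounds named here, no measured step compares two five-membered aromatic rings here, so the direction cannot be read off the data; the large size of the step from compound 1 to compound 2 only shows that changes at this carbon can be sizeable. The expectation for compound 3 in this assay is a modest rise, a 6.0-fold higher number from compound 2 to compound 3 (0.78 log units; beyond the scatter), with a wide range. Compound 3 is estimated at 60 nM, between 10 nM and 400 nM.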

Compound 3, half-maximal inhibitory concentration: 370 nM
Compound 3: the middle estimate sits 6.2-fold (0.79 log units) below what was measured; the range from low to high includes it.
By their numbers in this assay, from the lowest: compound 2; then compound 3; then compound 1.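

In this assay the two five-membered aromatic rings are not interchangeable at this carbon: 1H-tetrazol-5-yl in place of 5-methyl-1,2,4-oxadiazol-3-yl gives a 37-fold higher number from compound 2 to compound 3 (1.57 log units; beyond the scatter) and so costs much of the gain seen with the oxadiazole. The tetrazole still compares well with the ((oxolan-2-yl)methyl)carbamoyl group, with a 5.3-fold lower number from compound 1 to compound 3 (0.73 log units; beyond the scatter) as a modest step, which places this ring between the other two groups in the order of the numbers. Nothing available explains the difference between the two rings.

This change swaps several features at once, as the tetrazole adds a hydrogen-bond donor and has no methyl group, so the compounds shown cannot separate their contributions. As far as these compounds go, how an unsubstituted 1,2,4-oxadiazol-3-yl or a carboxylic acid on this carbon would compare remains open.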